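Compound 3: replacing 2-nitrophenyl with 2-chloro-4-fluorophenyl

This account rests on a few compounds, and the source may have more. Where it says the series, first, only, none or still open, it means among the compounds named here.

Within the data shown here, in a functional assay on HeLa cells (Homo sapiens) for cytotoxicity, read by MTT assay, with a stated time of 72 h (a lower number here means a stronger inhibitor, a higher number a weaker inhibitor), compound 2 (`O=C(/C=C/c1ccccc1[N+](=O)[O-])Nc1cc2c(Nc3ccc(F)c(Cl)c3)ncnc2cc1O[C@H]1CCOC1`) gives 29600 nM as the only number so far, so it has no rank against any other compound. For compound 1 (`N#Cc1ccc(/C=C/C(=O)Nc2cc3c(Nc4ccc(F)c(Cl)c4)ncnc3cc2O[C@H]2CCOC2)cc1`) the record reads "not determined" (no result reported) and offers no comparison. Compound 3 (`O=C(/C=C/c1ccc(F)cc1Cl)Nc1cc2c(Nc3ccc(F)c(Cl)c3)ncnc2cc1O[C@H]1CCOC1`) has 2-chloro-4-fluorophenyl in place of 2-nitrophenyl on a double-bonded chain carbon bound to a double-bonded chain carbon. Among the measured compounds shown here, no measured step exists to guide this change. A modest move toward stronger inhibition is expected in this assay (a 2.1-fold lower number from compound 2 to compound 3 (0.33 log units; beyond the scatter)). Compound 3 is estimated at 14000 nM (4000 nM to 50000 nM).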

Compound 3, half-maximal inhibitory concentration: 37500 nM
The estimate for compound 3 lay 2.7-fold (0.43 log units) below the measured number; low and high end bracket the measured number.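

In this assay the step of a 1.3-fold higher number from compound 2 to compound 3 (0.10 log units; within the scatter) shows that, at this position, 2-nitrophenyl and 2-chloro-4-fluorophenyl are not separated by the read-out. The two groups differ in their atoms and in hydrogen-bond acceptors, 2 against 0, yet that difference comes with no change beyond the scatter. No evidence bearing on this result is available. Still open, on these data alone, is whether an amine or a carboxylic acid in place of these groups on the same chain carbon, or a longer chain, would shift the number beyond the scatter.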